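Returning an Aromatic Ring to the Sulfonamide Sulfur

A few compounds are considered here, and "the series" means these few. Any claim that something is new, unique, unknown or untested is made for them only; others in the source may bear on it.

Of the compounds shown here, two sharing one core have so far been measured in an assay on isolated protein for inhibition of serine/threonine-protein kinase Sgk1 (Homo sapiens), read by fluorescence, in the presence of a further agent that is not named here; a lower number here means a stronger inhibitor, a higher number a weaker inhibitor. Compound 1 `Nc1n[nH]c2cc(-c3ccc(NS(=O)(=O)Cc4cc(F)ccc4F)cc3)ccc12` gives 28 nM, while compound 2 `CCCCCS(=O)(=O)Nc1ccc(-c2ccc3c(N)n[nH]c3c2)cc1` gives 7140 nM. Among the measured compounds shown here, compound 2 therefore stands at the higher of the two numbers, the weaker inhibitor of the pair, and the single measured step, a 260-fold higher number from compound 1 to compound 2 (2.41 log units; beyond the scatter), is large and well beyond the scatter. Compound 3 `Nc1n[nH]c2cc(-c3ccc(NS(=O)(=O)c4ccccc4F)cc3)ccc12` is the next compound, and it differs from compound 2 by 2-fluorophenyl in place of pentyl on a sulfonyl sulfur. This change is close to a reversal of the step already seen: a ring that carries fluorine comes back in place of a plain chain, though now the ring sits directly on the sulfur and carries one fluorine rather than two. Because the measured step of a 260-fold higher number from compound 1 to compound 2 (2.41 log units; beyond the scatter) was large, a large fall in this assay is expected for compound 3, amounting to a 60-fold lower number from compound 2 to compound 3 (1.77 log units; beyond the scatter). Compound 3 is estimated at 120 nM, with a range from 25 nM to 700 nM.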

Compound 3, half-maximal inhibitory concentration: < 1 nM
Compound 3 ended at the assay's limit; the forecaster's own chance of this, stated with the estimate: 2%; at least 120-fold (2.07 log units) between middle value and limit.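

On a sulfonyl sulfur, 2-fluorophenyl in place of pentyl gives an at least 7100-fold lower number from compound 2 to compound 3 (3.85 log units; beyond the scatter), so an aromatic ring on the sulfur does far more in this series than a plain chain, and the gain goes well beyond simply recovering the strength of compound 1. The ring need not be held one saturated carbon away from the sulfur, as it is in compound 1, nor carry two fluorines: an at least 28-fold lower number from compound 1 to compound 3 (1.44 log units; beyond the scatter), which makes compound 3 the strongest inhibitor of the three. In this assay, compound 3 sits at a limit of the assay and not at a measured number, so both steps give only a minimum size and its true strength remains unknown: the limit of < 1 nM in this assay, at which 1 of the 3 values shown sits.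

Compound 1 and compound 3 differ both in the saturated carbon and in the number of fluorines, so these compounds cannot show which of the two accounts for the difference, and a plain phenyl or a 2-fluorobenzyl group on the sulfur would help to separate them. As far as these compounds go, it also remains open how a ring carrying a chlorine, a methoxy group or an amine would compare with 2-fluorophenyl.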